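The source may report more compounds than this note shows. Statements on the series, on what has been measured and on what is new or still open speak of the compounds shown alone.

Working notes on the series.

Compound 1 `COc1cc(OC)c2sc(-c3ccc(N/C=C\C(=O)c4ccc(OC)c([N+](=O)[O-])c4)cc3)nc2c1` in a functional assay on A549 cells (Homo sapiens) for antiproliferative activity, read by sulforhodamine B assay, with a stated time of 48 h (a lower number here means a stronger inhibitor, a higher number a weaker inhibitor), gives 5800 nM. Compound 2 `COc1ccc2nc(-c3ccc(N/C=C\C(=O)c4ccc(OC)c([N+](=O)[O-])c4)cc3)sc2c1` in this assay gives 13600 nM; the difference between the core of compound 1 and the core of compound 2 is not broken down here, and the two values show compound 2 with the higher number, beyond the scatter. Compound 3 `COc1ccc(C(=O)/C=C\Nc2ccc(-c3nc4cc(OC)c(OC)c(OC)c4s3)cc2)cc1[N+](=O)[O-]` in this assay gives 21200 nM. From compound 1 to compound 3 the change is methoxy in place of hydrogen on an aromatic carbon, and the step is a 3.7-fold higher number from compound 1 to compound 3 (0.56 log units; beyond the scatter). The values of compound 2 and compound 3 lie within the scatter of each other.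

Compound 4 `COc1ccc2nc(-c3ccc(N/C=C\C(=O)c4cc(OC)c(OC)c([N+](=O)[O-])c4)cc3)sc2c1` is not yet measured. From compound 2 to compound 4 the change is methoxy in place of hydrogen on an aromatic carbon. This is the same kind of change as from compound 1 to compound 3, not the same change: in the earlier case the entering methoxy sits on a ring that is part of a fused or bridged system of two rings, ortho to two methoxy groups, meta to a fused ring and para to a fused ring; here it sits on a six-membered aromatic ring of carbon only, ortho to one methoxy group, meta to a large group and meta to a nitro group. The earlier instance, resting on a 3.7-fold higher number from compound 1 to compound 3 (0.56 log units; beyond the scatter), gave a higher number; with the surroundings not the same, the expected step in this assay is taken as a 1.6-fold higher number from compound 2 to compound 4 (0.21 log units; within the scatter), smaller and less certain than the earlier one. Compound 4 is estimated in this assay at 22000 nM, with a range from 8000 nM to 60000 nM.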

Compound 4, half-maximal inhibitory concentration: 21600 nM
Compound 4: the middle estimate sits 1.0-fold (0.01 log units) above what was measured; the range from low to high includes it.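

In this assay, methoxy in place of hydrogen on an aromatic carbon gives a 1.6-fold higher number from compound 2 to compound 4 (0.20 log units; within the scatter), which cannot be told apart from repeat measurement, while on the core of compound 1 the same kind of change gives a 3.7-fold higher number from compound 1 to compound 3 (0.56 log units; beyond the scatter). Set side by side, the two steps do not differ by more than two such steps can scatter: the same change on two cores in this assay, a 3.7-fold higher number (0.56 log units; beyond the scatter) from compound 1 to compound 3 and a 1.6-fold higher number (0.20 log units; within the scatter) from compound 2 to compound 4, 2.3-fold (0.36 log units) apart, within the scatter of two such steps. This shows no measurable dependence of the step on the core across these two pairs, but it does not show that the change transfers with the same size, since it rests on only two instances, the methoxy enters at different places in them, and one of the two steps is itself within the scatter.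

The compounds shown leave open how an amine, a hydroxy group or a carboxylic acid would read in this assay in place of the entering methoxy on the six-membered aromatic ring of carbon only, and whether an ethoxy group or a longer chain would read like methoxy there. They also leave open whether the step would hold with a nitrile in place of the nitro group.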